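A few compounds are considered here, and "the series" means these few. Any claim that something is new, unique, unknown or untested is made for them only; others in the source may bear on it.

Measured in a functional assay on SW1573 cells (Homo sapiens) for antiproliferative activity, read by sulforhodamine B assay, with a stated time of 48 h; a lower number here means a stronger inhibitor of growth, a higher number a weaker inhibitor of growth:
Compound 1 `CC(C)(C)[Si](C)(C)O[C@@H]1CCCO[C@@H]1/C=C/C(=O)OCc1ccccc1`: 37000 nM
Compound 2 `O=C(/C=C/[C@H]1OCCC[C@H]1O)OCc1ccccc1`: > 100000 nM (a limit, not a number)

Within the data shown here, compound 1 is the only compound here with an actual number, so it is the reference point. For compound 2, the value > 100000 nM is a limit. This places compound 2 at the limit of > 100000 nM in this assay, at which 1 of the 2 values shown sits.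

Compound 3 `CC(C)(C)[Si](C)(C)O[C@@H]1CCCO[C@@H]1/C=C\C(=O)OCc1ccccc1` has not yet been measured. The change to it is the two compounds have the same atoms and bonds and differ only in configuration as drawn: 1 of 3 stereo elements differ; a double bond is drawn E in compound 1 and Z in compound 3: a double bond is drawn E in compound 1 and Z in compound 3.

Among the measured compounds shown here, the one measured step is an at least 2.7-fold higher number from compound 1 to compound 2 (0.43 log units; beyond the scatter). It replaces a group on an oxygen with a hydrogen atom, and compound 3 keeps that group. For the measured compounds named here, this step therefore says little about the double bond, and no measured step tests that change directly. With no evidence for a shift in either direction, no change beyond the scatter is expected in this assay, though the uncertainty is wide. The estimated step is a 1.1-fold lower number from compound 1 to compound 3 (0.02 log units; within the scatter). For compound 3 the estimated value is 35000 nM, with an expected range from 12000 nM to 100000 nM.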

Compound 3, concentration for 50% growth inhibition: 26000 nM
Beside the measured number, compound 3's estimate is 1.3-fold (0.13 log units) above it; the measured number falls inside the stated range.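

In this assay, turning the double bond from E to Z gives a 1.4-fold lower number from compound 1 to compound 3 (0.15 log units; within the scatter). Among these compounds, this is the first direct test of the double bond, since the earlier step changed only the group on the oxygen, and with that silicon-containing group kept in place, this assay does not separate the two geometries. The comparison isolates the double bond, with nothing else in the structures to account for the result: the fact that compounds 1 and 3 differ only in the configuration as drawn

On these data alone, whether the geometry would matter with a hydrogen atom on that oxygen, as in compound 2, remains open. Also open, as far as these compounds go, is how growth inhibition would respond if a carboxylic acid or an amide replaced the benzyl ester on the shared core.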